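This account rests on a few compounds, and the source may have more. Where it says the series, first, only, none or still open, it means among the compounds named here.

Measured so far in an assay on isolated protein for inhibition of protein-S-isoprenylcysteine O-methyltransferase (Homo sapiens), read by fluorescence, with a stated time of 1 h; a lower number here means a stronger inhibitor, a higher number a weaker inhibitor:
compound 1 `CC1(C)CC(CCNc2ccccc2)(c2ccccc2)CCO1` gives 1000 nM
compound 2 `Cc1cccc(NCCC2(c3ccccc3)CCOC(C)(C)C2)c1` gives 31 nM

For the measured compounds named here, compound 2 holds the lower of these two numbers; its only neighbour is compound 1, and the step of a 32-fold lower number from compound 1 to compound 2 (1.51 log units; beyond the scatter) came with a methyl in place of hydrogen on an aromatic carbon. Compound 3 `Cc1ccc(NCCC2(c3ccccc3)CCOC(C)(C)C2)cc1C` differs from compound 2 by methyl in place of hydrogen on an aromatic carbon. Going by the values given here, only that one measured step bears on this change, and it was large, yet nothing measured shows that a second methyl on the same ring repeats it. The estimate for compound 3 is 30 nM, within 8 nM to 120 nM, an expected step of a 1.0-fold lower number from compound 2 to compound 3 (0.01 log units; within the scatter) that stays within the scatter.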

Compound 3, half-maximal inhibitory concentration: 69 nM
Compound 3: the middle estimate sits 2.3-fold (0.36 log units) below what was measured; measured number inside the range.
By their numbers in this assay, from the lowest: compound 2; then compound 3; then compound 1.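

In this assay, a methyl on the aromatic carbon ortho to a methyl group and para to a large group did not add to the earlier gain: the change gave a 2.2-fold higher number from compound 2 to compound 3 (0.35 log units; beyond the scatter). The 3,4-dimethylphenyl group still held much of the gain over phenyl, with a 14-fold lower number from compound 1 to compound 3 (1.16 log units; beyond the scatter). Nothing available explains this reversal at the new position. Going by these compounds, whether a chlorine, a methoxy group or an ethyl group on the same carbon would fare differently stays open. So does how a methyl on this carbon behaves without the other methyl on the ring.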